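Aryl for Cyclohexenyl on an Inactive Triazole Series

The source may report more compounds than this note shows. Statements on the series, on what has been measured and on what is new or still open speak of the compounds shown alone.

Measured compounds:
compound 1 `O=C1NC(O)(CCn2cc(C3=CCCCC3)nn2)C(OCc2ccccc2)=C1OCc1ccccc1` – > 100000 nM
compound 2 `O=C1O/C(=C\Cn2cc(-c3ccccn3)nn2)C(OCc2ccccc2)=C1OCc1ccccc1` – > 100000 nM
compound 3 `COC1=C(OC)C(O)(CCn2cc(-c3ccc(C(C)(C)C)cc3)nn2)NC1=O` – > 100000 nM

In a functional assay on MCF7 cells (Homo sapiens) for antiproliferative activity, read by MTT assay, with a stated time of 24 h (a lower number here means a stronger inhibitor, a higher number a weaker inhibitor), compound 1 gives > 100000 nM, which is a limit of the assay and not a number. Compound 2 likewise gives > 100000 nM in this assay, again a limit. Compound 3 gives > 100000 nM in this assay, also a limit. Compound 1 therefore stands nowhere in particular on the numbers shown: all three values sit at the limit of > 100000 nM in this assay, at which 3 of the 3 values shown sit, so none of the three can be ordered against another.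

Compound 4 `Cc1ccc(-c2cn(CCC3(O)NC(=O)C(OCc4ccccc4)=C3OCc3ccccc3)nn2)cc1` has not yet been measured. It differs from compound 1 in one place: 4-methylphenyl in place of cyclohex-1-en-1-yl on an aromatic carbon, in words 4-methylphenyl in place of cyclohex-1-en-1-yl on an aromatic carbon. For the measured compounds named here, no measured step is available to gauge what such a change does in this assay.

Given that compound 1 sits at the limit and that compound 3, which also carries an aryl group on the triazole, sits at the same limit > 100000 nM, the step from compound 1 to compound 4 is expected to be a number no higher from compound 1 to compound 4 (the limit leaves the size open), that is, no movement beyond the scatter. Compound 4 is expected to give about 100000 nM, between 30000 nM and 300000 nM, most likely reported as a limit.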

Compound 4, half-maximal inhibitory concentration: 24000 nM
The estimate for compound 4 lay 4.2-fold (0.62 log units) above the measured number, and the stated range ends above it.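

In this assay, the aromatic carbon of the five-membered ring with 3 nitrogen proves to be a place where a change can register: 4-methylphenyl in place of cyclohex-1-en-1-yl gives an at least 4.1-fold lower number from compound 1 to compound 4 (0.61 log units; beyond the scatter). For the compounds shown here, the step is beyond the scatter, and it is the first sign in this set that the read-out moves at all, which the earlier compounds could not show, as each of them gives only a limit and none can be ordered against another: the limit of > 100000 nM in this assay, at which 3 of the 4 values shown sit. The step sets only a lower bound on the size of the change, so the exchange of a non-aromatic ring for a methyl-bearing aromatic one is known to matter, but not by how much.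

The compounds shown leave open whether the gain belongs to the aromatic ring itself or to its methyl group, which a plain phenyl group at the same place would separate. They also leave open how a 4-methoxyphenyl group, or an amine or a carboxylic acid on that ring, would read in this assay.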